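The compounds below may be only part of what the source reports. "The series", "measured", "known", "first", "only" and "open" are said of these compounds alone.

Measured compounds in an ADME assay on a cell-free system (plasma, Homo sapiens) for metabolic stability, with Plasma (Rattus norvegicus) as the target, read by HPLC, at pH 7.4; a lower number here means that the compound disappears faster, a higher number that the compound lasts longer:
compound 1, `CC(=O)Oc1ccccc1C(=O)O[C@H]1CO[C@H]2[C@@H]1OC[C@H]2OC(=O)c1ccccc1O`, gives 0.0825 h
compound 2, `CC(=O)Oc1ccccc1C(=O)O[C@H]1CO[C@H]2[C@@H]1OC[C@H]2OC(=O)c1ccnn1C`, gives 0.0963 h
compound 3, `CC(=O)Oc1ccccc1C(=O)O[C@H]1CO[C@H]2[C@@H]1OC[C@H]2OC(=O)c1ccc(O)cc1`, gives 0.0198 h

Compound 3 holds the lowest number of the three in this assay; the steps to the other two, a 4.2-fold lower number from compound 1 to compound 3 (0.62 log units; beyond the scatter) and a 4.9-fold lower number from compound 2 to compound 3 (0.69 log units; beyond the scatter), both lie beyond the scatter, while compound 1 and compound 2 sit within the scatter of each other, a 1.2-fold higher number from compound 1 to compound 2 (0.07 log units; within the scatter).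

Compound 4, `CCCCC(=O)O[C@@H]1CO[C@H]2[C@@H]1OC[C@@H]2OC(=O)c1ccccc1OC(C)=O`, is not yet measured. It differs from compound 3 in one place: butyl in place of 4-hydroxyphenyl on a carbonyl carbon

Among the compounds with values here, no measured step introduces butyl, so the bearing of the known steps is indirect. Both steps that leave compound 3, read in reverse, show that swapping the 4-hydroxyphenyl on that carbonyl carbon for another group moved the number upward by a modest margin, beyond the scatter. On that basis a modest rise in this assay is expected for compound 4, with wide uncertainty since butyl is unlike either group tried. The estimate for compound 4 is 0.06 h, range 0.015 h to 0.25 h, i.e. an expected step of a 3.0-fold higher number from compound 3 to compound 4 (0.48 log units; beyond the scatter).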

Compound 4, half-life: 0.0198 h
The estimate for compound 4 lay 3.0-fold (0.48 log units) above the measured number; low and high end bracket the measured number.
By their numbers in this assay, from the lowest: compounds 3 and 4 (each within the scatter of the next); then compounds 1 and 2 (each within the scatter of the next).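

In this assay, butyl on this carbonyl carbon gives no separation from 4-hydroxyphenyl (no change at the digits printed from compound 3 to compound 4 (within the scatter)), so leaving 4-hydroxyphenyl does not by itself raise the number. Butyl also stands apart from the other two groups (a 4.9-fold lower number from compound 2 to compound 4 (0.69 log units; beyond the scatter)) (a 4.2-fold lower number from compound 1 to compound 4 (0.62 log units; beyond the scatter)), which places compound 4 with compound 3 in the lower pair. Among these compounds, a ring or hydrogen-bond donor in this group is therefore not needed for the lower number, although nothing available explains why these groups separate as they do.

Going by these compounds, it remains open whether a longer chain, a branched chain such as tert-butyl, or a chain ending in an amine or carboxylic acid would stay with butyl. Also open, on these data alone, is whether a 3-hydroxyphenyl group would fall with compound 3 or with compound 1.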